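The compounds below may be only part of what the source reports. "The series", "measured", "known", "first", "only" and "open" are said of these compounds alone.

Of the compounds shown here, three have been measured in an ADME assay on microsomes from liver (Mus musculus) for metabolic stability, with a stated time of 10 min; a higher number here means that more of the compound is left, a lower number that less of the compound is left. Compound 1 `CC(=O)N1CC[C@H](C(=O)N2CC[C@](c3ccc(C(OCc4c(F)cccc4F)(C(F)(F)F)C(F)(F)F)cc3)(S(=O)(=O)c3ccc(F)cc3)C2)C1` gives 57% and compound 2 `CC(=O)N1CC[C@@H](C(=O)N2CC[C@](c3ccc(C(OCc4c(F)cccc4F)(C(F)(F)F)C(F)(F)F)cc3)(S(=O)(=O)c3ccc(F)cc3)C2)C1` gives 55%. What separates these two is the fact that compounds 1 and 2 differ only in the configuration as drawn, and the step is a number 2 percentage points lower from compound 1 to compound 2 (within the scatter). Compound 3 `Cc1cccc(C)c1COC(c1ccc([C@]2(S(=O)(=O)c3ccc(F)cc3)CCN(C(=O)[C@H]3CC[C@H](C(=O)O)CC3)C2)cc1)(C(F)(F)F)C(F)(F)F` stands highest of the three at 77%, and its gap to each of the other two lies beyond the usual scatter.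

Compound 4 `O=C(O)[C@H]1CC[C@H](C(=O)N2CC[C@](c3ccc(C(OCC4CCCCC4)(C(F)(F)F)C(F)(F)F)cc3)(S(=O)(=O)c3ccc(F)cc3)C2)CC1` is built like compound 3 apart from one group: cyclohexyl in place of 2,6-dimethylphenyl on a saturated chain carbon bound to an oxygen on a saturated carbon. Cyclohexyl takes the place of 2,6-dimethylphenyl on a saturated chain carbon bound to an oxygen on a saturated carbon, so 2,6-dimethylbenzyl becomes cyclohexylmethyl.

Among the compounds with values here, no measured step makes this swap. Within the data shown here, the only step available, a number 2 percentage points lower from compound 1 to compound 2 (within the scatter), concerns configuration alone and is a weak guide here, so no step beyond the scatter is expected in this assay. Among the measured compounds shown here, with compound 3 at 77%, the top of the numbers so far, a small fall is expected rather than a rise. The expected change is a number 7 percentage points lower from compound 3 to compound 4 (within the scatter), which would stay within the scatter. For compound 4 the estimated value is 70%, with an expected range from 50% to 86%.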

Compound 4, percent of the compound remaining: 78%
For compound 4 the middle estimate is 8 percentage points below the measured one, and the stated range covers the measured number.
By their numbers in this assay, from the lowest: compounds 2 and 1 (each within the scatter of the next); then compounds 3 and 4 (each within the scatter of the next).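

In this assay, replacing 2,6-dimethylphenyl with cyclohexyl on a saturated chain carbon bound to an oxygen on a saturated carbon gives a number 1 percentage points higher from compound 3 to compound 4 (within the scatter). Within the data shown here, the only earlier step changed configuration alone, so this is the first reading of a change in the group itself at this place: a six-membered aromatic ring of carbon only, with 8 heavy atoms, gives way to a six-membered non-aromatic ring of carbon only, with 6, and this pair of compounds cannot be told apart in this read-out, so here the aromatic ring is not needed to keep the compound at this level. Nothing measured here says why the two groups read alike, and the one available fact about the series concerns another kind of change.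

The compounds shown leave open how a pyridyl ring, which brings a ring nitrogen, or an open chain such as n-butyl would read at this place. They also leave open whether the same swap would read alike with the other groups of compound 1 in place of those of compound 3.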